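A few compounds are considered here, and "the series" means these few. Any claim that something is new, unique, unknown or untested is made for them only; others in the source may bear on it.

Measured so far:
- compound 1 `COc1cc(/C=C/C(=O)c2cccc(N)c2)ccc1O`: 50%
- compound 2 `COc1cc(/C=C/C(=O)c2cccc(NC(=O)c3ccc(Cl)cc3Cl)c2)ccc1O`: 51%
- compound 3 `COc1cc(/C=C/C(=O)c2cccc(NC(=O)c3ccc(Cl)c(Cl)c3)c2)ccc1O`: 5%

In a functional assay on HUVEC cells (Homo sapiens) for inhibition, tested at 5 ug/mL (a higher number here means a stronger effect of the compound at the concentration tested, a lower number a weaker effect), compound 2 stands highest of the three numbers, with compound 1 within the scatter (a number 1 percentage points higher from compound 1 to compound 2 (within the scatter)) and compound 3 far beyond it (a number 46 percentage points lower from compound 2 to compound 3 (beyond the scatter)). Compound 4 `CCCC(=O)Nc1cccc(C(=O)/C=C/c2ccc(O)c(OC)c2)c1` is the next candidate; against compound 2 it differs as follows: propyl in place of 2,4-dichlorophenyl on a carbonyl carbon. Among the compounds with values here, no measured step replaces a dichlorophenyl by a chain on this carbonyl carbon. The steps that touch the group on that carbon are a number 1 percentage points higher from compound 1 to compound 2 (within the scatter) and a number 45 percentage points lower from compound 1 to compound 3 (beyond the scatter): one dichlorophenyl leaves the read-out unchanged, the other removes most of it, so the read-out depends strongly on what sits there, and a propyl lies outside both measured cases. A drop of moderate size is expected, with wide uncertainty. Compound 4 is estimated at 35% (range 5% to 60%), which means an expected step of a number 16 percentage points lower from compound 2 to compound 4 (beyond the scatter).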

Compound 4, a percentage reported as inhibition, at one concentration (the size of the read-out at that concentration, not a potency): 57%
Compound 4: middle estimate off by 22 percentage points, on the low side; measured number inside the range.
By their numbers in this assay, from the lowest: compound 3; then compounds 1, 2 and 4 (each within the scatter of the next).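

In this assay, an aromatic group on this carbonyl carbon is not required: propyl in place of 2,4-dichlorophenyl changes nothing beyond the scatter (a number 6 percentage points higher from compound 2 to compound 4 (within the scatter)), and the same holds for propylcarbonyl on the nitrogen (a number 7 percentage points higher from compound 1 to compound 4 (within the scatter)). Among the three amides, the 3,4-dichlorophenyl group alone stands apart (a number 52 percentage points higher from compound 3 to compound 4 (beyond the scatter)), so acylating the nitrogen does not by itself cost the read-out. No available data bear on why this group differs. Open: whether a longer chain, an unsubstituted phenyl or a 3-chlorophenyl on this carbon keeps the read-out. One concentration gives no potency ranking.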